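Methoxy added to the phenyl of compound 2

The compounds below may be only part of what the source reports. "The series", "measured", "known", "first", "only" and "open" are said of these compounds alone.

The pair measured so far sets the scene. Compound 1 `Brc1cn2ccnc2c(-c2ccc3ncn(C4CCCCC4)c3c2)n1` gives 18% in a functional assay on HL-60 cells (Homo sapiens) for inhibition, read by sulforhodamine B assay, with a stated time of 48 h, tested at 10 uM (a higher number here means more inhibition at the concentration tested (going by the name of the read-out), a lower number less inhibition), whereas compound 2 `c1ccc(-c2cn3ccnc3c(-c3ccc4ncn(C5CCCCC5)c4c3)n2)cc1` gives 67.1% in this assay. Within the data shown here, compound 2 therefore stands highest of the two numbers known, and the one measured step, a number 49.1 percentage points higher from compound 1 to compound 2 (beyond the scatter), is the only guide available. The next compound, compound 3 `COc1ccc(-c2cn3ccnc3c(-c3ccc4ncn(C5CCCCC5)c4c3)n2)cc1`, keeps the whole of compound 2 and differs only in one respect: methoxy in place of hydrogen on an aromatic carbon. Among the measured compounds shown here, the measured step concerned the arrival of the phenyl itself and was large; it does not speak directly to a substituent on that phenyl, and no measured pair here involves methoxy at all. On that basis the step of a number 2.9 percentage points higher from compound 2 to compound 3 (within the scatter) is expected to be small, likely within the scatter, with a slight lean upward. Compound 3 is thus estimated at 70% in this assay, within a range from 50% to 88%.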

Compound 3, a percentage reported as inhibition, at one concentration (the size of the read-out at that concentration, not a potency): 98.6%
For compound 3 the middle estimate is 28.6 percentage points below the measured one; measured number outside the range, above it.
By their numbers in this assay, from the lowest: compound 1; then compound 2; then compound 3.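

In this assay, the phenyl of compound 2 turns out not to be the limit of the gain: methoxy in place of hydrogen on an aromatic carbon, para to a large group, gives a number 31.5 percentage points higher from compound 2 to compound 3 (beyond the scatter). The earlier pair showed only what the arrival of the phenyl did, whereas this step shows that the number also responds to a substituent on that ring. Taken as a whole, 4-methoxyphenyl in place of bromo gives a number 80.6 percentage points higher from compound 1 to compound 3 (beyond the scatter). No evidence here accounts for this gain.

On these data alone, it remains open whether the rise is particular to methoxy or would also appear with a hydroxy group, an amine or a longer chain such as butoxy at this place. With compound 3 at 98.6%, any further gain from such groups would have little room to show in this assay.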